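Replacing hydroxy in compound 3 with (4-methylpiperazin-1-yl)methyl

A few compounds are considered here, and "the series" means these few. Any claim that something is new, unique, unknown or untested is made for them only; others in the source may bear on it.

In a functional assay on A549 cells (Homo sapiens) for antiproliferative activity, read by MTT assay, with a stated time of 48 h (a lower number here means a stronger inhibitor, a higher number a weaker inhibitor), compound 3 `N#Cc1nc2c(-c3nc4ccccc4[nH]3)c(N)n(CCO)c2nc1C#N` gives only a limit, > 50000 nM. Compound 1 `CCn1c(N)c(-c2nc3ccccc3[nH]2)c2nc(C#N)c(C#N)nc21` also gives only a limit, > 50000 nM. Both therefore stand at the limit of > 50000 nM in this assay, at which 2 of the 3 values shown sit. Compound 2 `CCCn1c(N)c(-c2nc3ccccc3[nH]2)c2nc(C#N)c(C#N)nc21` gives a true number, 1970 nM. Two large measured steps bear on the change: an at least 25-fold lower number from compound 1 to compound 2 (1.40 log units; beyond the scatter) and an at least 25-fold higher number from compound 2 to compound 3 (1.40 log units; beyond the scatter). Compound 4 `CN1CCN(CCCn2c(N)c(-c3nc4ccccc4[nH]3)c3nc(C#N)c(C#N)nc32)CC1` differs from compound 3 by (4-methylpiperazin-1-yl)methyl in place of hydroxy on a saturated chain carbon, two bonds along the chain from an aromatic nitrogen, with (4-methylpiperazin-1-yl)methyl in place of hydroxy on a saturated chain carbon. Like compound 2, it carries carbon there, so the step of an at least 25-fold higher number from compound 2 to compound 3 (1.40 log units; beyond the scatter) is expected to reverse at least in large part. The expected change is a large fall, an at least 12-fold lower number from compound 3 to compound 4 (1.09 log units; beyond the scatter). Compound 4 is estimated at 4000 nM, within a range of 800 nM to 20000 nM.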

Compound 4, half-maximal inhibitory concentration: 5750 nM
Compound 4: the middle estimate sits 1.4-fold (0.16 log units) below what was measured, and the stated range covers the measured number.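

In this assay, the position takes the 8 heavy atoms of (4-methylpiperazin-1-yl)methyl and activity stays readable, with an at least 8.6-fold lower number from compound 3 to compound 4 (0.93 log units; beyond the scatter) and an at least 8.6-fold lower number from compound 1 to compound 4 (0.93 log units; beyond the scatter). Compared with the plain chain, the added ring still costs activity, with a 2.9-fold higher number from compound 2 to compound 4 (0.47 log units; beyond the scatter). The two steps from compound 1 and compound 3 give only a minimum size, as both of those compounds stand at a limit: the limit of > 50000 nM in this assay, at which 2 of the 4 values shown sit.

From the compounds shown here alone, what stays open is whether the ring's amine nitrogens matter or only the length of the chain. A morpholine or a plain butyl chain at this place would bear on that.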